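A few compounds are considered here, and "the series" means these few. Any claim that something is new, unique, unknown or untested is made for them only; others in the source may bear on it.

Measured so far in a functional assay on U-87MG ATCC cells for antiproliferative activity against U-87 MG (Homo sapiens), read by MTT assay, with a stated time of 48 h, tested at 50 uM; on this read-out lower numbers stand for a stronger effect and higher numbers for a weaker effect at the one concentration tested:
- compound 1 `COc1ccc(-c2nc(SCC(=O)c3sc(-c4ccccc4)nc3C)[nH]c(=O)c2C#N)cc1`: 52.1%
- compound 2 `COc1ccc(-c2nc(SCC(=O)c3sc(-c4ccccc4)nc3C)[nH]c(=O)c2C#N)cc1OC`: 21.4%
- compound 3 `COc1ccc(-c2nc(SCC(=O)c3sc(-c4ccc(Cl)cc4)nc3C)[nH]c(=O)c2C#N)cc1OC`: 59.8%

Compound 3 gives the highest of the three numbers, but the gap to compound 1 lies within the scatter; only compound 2 stands clearly lower. Compound 4 `COc1cccc(-c2nc(SCC(=O)c3sc(-c4ccc(Cl)cc4)nc3C)[nH]c(=O)c2C#N)c1` differs from compound 3 by hydrogen in place of methoxy on an aromatic carbon, that is, 3,4-dimethoxyphenyl becoming 3-methoxyphenyl. Going by the values given here, the one step of this kind on that ring is a number 30.7 percentage points lower from compound 1 to compound 2 (beyond the scatter), which ran the other way, from hydrogen to methoxy; read in reverse it points upward. The step of a number 38.4 percentage points higher from compound 2 to compound 3 (beyond the scatter) concerns the chloro group and does not bear directly. A small rise or no step beyond the scatter is expected: a number 4.2 percentage points higher from compound 3 to compound 4 (within the scatter). Compound 4 is estimated at 64%, range 46% to 82%.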

Compound 4, a percentage reported as activity, at one concentration (the size of the read-out at that concentration, not a potency): 47.6%
Compound 4: the middle estimate sits 16.4 percentage points above what was measured, and the stated range covers the measured number.
By their numbers in this assay, from the lowest: compound 2; then compounds 4, 1 and 3 (each within the scatter of the next, the first and the last beyond it).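

In this assay, hydrogen in place of methoxy gives a number 12.2 percentage points lower from compound 3 to compound 4 (beyond the scatter), so with the chloro group present, 3-methoxyphenyl gives the stronger effect of the pair, not 3,4-dimethoxyphenyl. The effect of adding a methoxy on this ring does not carry from one core to the other, and its direction reverses: the same change on two cores in this assay, a number 30.7 percentage points lower (beyond the scatter) from compound 1 to compound 2 and a number 12.2 percentage points higher (beyond the scatter) from compound 4 to compound 3, 42.9 percentage points apart, beyond the scatter of two such steps

From the compounds shown here alone, only hydrogen and chloro appear on the other phenyl ring, so whether the reversal is specific to chloro remains open. Going by these compounds, how a hydroxy group or an amine would read in place of this methoxy also remains open.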